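This account rests on a few compounds, and the source may have more. Where it says the series, first, only, none or still open, it means among the compounds named here.

Measured so far:
compound 1 `CNC(=O)c1cc(-c2cnc(NCc3c(F)ccc4c3CCO4)c3cn[nH]c(=O)c23)n(C)n1`: < 3 mL.min-1.g-1
compound 2 `CN(C)Cc1ccc(C(=O)Nc2cnc(NCc3c(F)ccc4c3CCO4)n3cnnc23)cc1`: 13 mL.min-1.g-1
compound 3 `C[C@H]1CC(=O)N(c2cnc(NCc3c(F)ccc4c3CCO4)n3cnnc23)C1`: < 3 mL.min-1.g-1

All three were tested in an ADME assay on microsomes from liver (Homo sapiens) for metabolic stability, read by LC-MS, using NADPH, with stated times of 5 min and 30 min, tested at 1 uM; a higher number here means faster removal of the compound, a lower number slower removal. Compound 1 gives < 3 mL.min-1.g-1 there, which is a limit of the measurement rather than a number. Compound 3 likewise gives only a limit, < 3 mL.min-1.g-1. Compound 2 gives 13 mL.min-1.g-1. Compound 1 therefore stands at the limit of < 3 mL.min-1.g-1 in this assay, at which 2 of the 3 values shown sit, alongside compound 3, while compound 2 sits higher.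

Compound 4 `Cc1ncccc1-c1cnc(NCc2c(F)ccc3c2CCO3)c2cn[nH]c(=O)c12` has not yet been measured. It differs from compound 1 in one place: 2-methylpyridin-3-yl in place of 1-methyl-3-(methylcarbamoyl)-1H-pyrazol-5-yl on an aromatic carbon. For the measured compounds named here, no measured pair shows what this exchange does, so the expectation rests on compound 1 alone. Since compound 1 sits at a limit, the only visible move is upward, and a modest rise is expected, an at least 2.0-fold higher number from compound 1 to compound 4 (0.30 log units; that floor lies within the scatter). Compound 4 is estimated at 6 mL.min-1.g-1, between 3 mL.min-1.g-1 and 15 mL.min-1.g-1.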

Compound 4, intrinsic clearance in microsomes: 41 mL.min-1.g-1
Beside the measured number, compound 4's estimate is 6.8-fold (0.83 log units) below it; the whole stated range lies below it.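

At this position on the shared core, the group strongly affects the result in this assay: 2-methylpyridin-3-yl in place of 1-methyl-3-(methylcarbamoyl)-1H-pyrazol-5-yl gives an at least 13-fold higher number from compound 1 to compound 4 (1.13 log units; beyond the scatter). Compound 1 has only a limit of the assay rather than a number, and the true size of the step stays unknown: the limit of < 3 mL.min-1.g-1 in this assay, at which 2 of the 4 values shown sit.

The exchange alters the ring and removes the methylcarbamoyl group at once, and the compounds shown do not separate these two changes. Nor do they show what 1-methyl-1H-pyrazol-5-yl without the methylcarbamoyl group, or pyridin-3-yl without its methyl, would give here.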